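The source may report more compounds than this note shows. Statements on the series, on what has been measured and on what is new or still open speak of the compounds shown alone.

Measured compounds:
- compound 1 `COc1cc(NC(=O)Nc2cc(Nc3cc(Br)ccc3OC)ncn2)cc(OC)c1`: 42.7%
- compound 2 `COc1cc(Nc2cc(NC(=O)Nc3c(Cl)cccc3Cl)ncn2)cc(OC)c1`: 60%
- compound 3 `COc1cc(Nc2cc(NC(=O)Nc3c(Cl)cccc3Cl)ncn2)cc(C(F)(F)F)c1`: 33.1%

All three were tested in a functional assay on NCI-H226 cells (Homo sapiens) for inhibition, read by MTT assay, with a stated time of 48 h, tested at 10 uM; a lower number here means less inhibition, a higher number more inhibition at the concentration tested (going by the name of the read-out). Among them compound 1 stands second highest. Its nearest neighbour is compound 3, whose value lies within the scatter of that of compound 1, so no order between these two can be claimed. Compound 2 lies beyond the scatter above compound 1. Among the compounds with values here, the only step between compounds that differ in a single place is a number 26.9 percentage points lower from compound 2 to compound 3 (beyond the scatter), and that change sits on the aryl attached through the urea, not on the nitrogen that carries the change considered here.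

Compound 4 `COc1cc(NC(=O)Nc2cc(Nc3ccc(C(C)(C)C)cc3)ncn2)cc(OC)c1` is not yet measured in this assay. It differs from compound 1 in one place: 4-(tert-butyl)phenyl in place of 5-bromo-2-methoxyphenyl on a nitrogen on an aromatic ring. Within the data shown here, no measured step touches this position, and compound 1 and compound 2 differ in more than one place, so their values cannot be read as a single change. There is therefore no measured basis for a step in either direction, and the expectation is a step from compound 1 to compound 4 of a number 2.7 percentage points lower from compound 1 to compound 4 (within the scatter), within the scatter. For compound 4 in this assay the estimate is 40%, with a range from 20% to 60%.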

Compound 4, a percentage reported as inhibition, at one concentration (the size of the read-out at that concentration, not a potency): 47.7%
Estimate against measurement, compound 4: 7.7 percentage points below, within the range that was stated.
By their numbers in this assay, from the lowest: compounds 3, 1 and 4 (each within the scatter of the next, the first and the last beyond it); then compound 2.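

Within the data shown here, at the nitrogen on an aromatic ring, putting 4-(tert-butyl)phenyl in place of 5-bromo-2-methoxyphenyl gives, in this assay, a number 5 percentage points higher from compound 1 to compound 4 (within the scatter), the first measured step at this position. The two groups share one six-membered aromatic ring of carbon only, but the entering group is all carbon and holds neither the bromine nor the oxygen of the group it replaces, and this exchange leaves no difference that can be claimed between the two compounds, so for this pair the read-out does not depend on which of the two aryl groups is present. Nothing measured here offers an explanation for this outcome.

Among these compounds, since this single pair is the only reading at this position, it remains open whether a group of a different kind on the same nitrogen, such as a morpholine, a carboxylic acid or a longer alkyl chain, would produce a step beyond the scatter. Going by these compounds, it also remains open whether the bromine and the methoxy of 5-bromo-2-methoxyphenyl would each give the same result if exchanged separately.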